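Compound 4: the fluorophenyl isomer of compound 1

This account rests on a few compounds, and the source may have more. Where it says the series, first, only, none or still open, it means among the compounds named here.

Compound 1 `COc1nc2ccc(Br)cc2cc1C(c1ccccc1)n1cc(-c2ccccc2F)nn1` gives 7.33% in an ADME assay on SK-OV-3 cells (Homo sapiens) for cytotoxicity, read by sulforhodamine B assay, with a stated time of 48 h, tested at 10 uM; on this read-out lower numbers stand for less inhibition and higher numbers for more inhibition at the one concentration tested (going by the name of the read-out). Compound 2 `COc1nc2ccc(Br)cc2cc1C(c1ccccc1)n1cc(CCCO)nn1` gives 13.8% in this assay, and compound 3 `CCCc1cn(C(c2ccccc2)c2cc3cc(Br)ccc3nc2OC)nn1` gives 11.2% in this assay. Compound 1 holds the lowest of the three numbers, yet all three sit within the usual scatter of one another: the nearest is a number 3.9 percentage points higher from compound 1 to compound 3 (within the scatter), the furthest is a number 6.5 percentage points higher from compound 1 to compound 2 (within the scatter), and the remaining pair shows a number 2.6 percentage points lower from compound 2 to compound 3 (within the scatter). Nothing in this set separates one compound from another.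

Compound 4 `COc1nc2ccc(Br)cc2cc1C(c1ccccc1)n1cc(-c2cccc(F)c2)nn1` differs from compound 1 by 3-fluorophenyl in place of 2-fluorophenyl on an aromatic carbon. For the measured compounds named here, no measured step moves fluorine around the ring; the two steps from compound 1 exchange the entire 2-fluorophenyl for a 3-hydroxypropyl or a propyl chain, and even these larger changes stay within the scatter. A shift of fluorine alone within the same ring is therefore expected to produce no step beyond the scatter, and the expected step is a number 1.7 percentage points higher from compound 1 to compound 4 (within the scatter). Compound 4 is estimated at 9% in this assay, with an expected range from 0% to 22%.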

Compound 4, a percentage reported as inhibition, at one concentration (the size of the read-out at that concentration, not a potency): 12.7%
Compound 4: middle estimate off by 3.7 percentage points, on the low side; the range from low to high includes it.
By their numbers in this assay, from the lowest: compounds 1, 3, 4 and 2 (each within the scatter of the next).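

On the aromatic carbon of the five-membered ring, 3-fluorophenyl in place of 2-fluorophenyl keeps the same atoms joined differently, and in this assay this gives a number 5.4 percentage points higher from compound 1 to compound 4 (within the scatter), so at the one concentration tested this read-out does not separate these two placements of fluorine on the phenyl ring. The 3-fluorophenyl group also cannot be told apart from either chain at this position, with a number 1.5 percentage points higher from compound 3 to compound 4 (within the scatter) against propyl and a number 1.1 percentage points lower from compound 2 to compound 4 (within the scatter) against 3-hydroxypropyl, so all four compounds, aryl and chain alike, now stand within the scatter of one another. No measurement at hand offers an explanation for any of these numbers.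

As far as these compounds go, it remains open whether any group on this carbon can move the number beyond the scatter, for example a 3-aminopropyl chain, a carboxylic acid or a longer alkyl chain. From the compounds shown here alone, since a single-concentration percentage is not a potency, it is also open whether compounds that cannot be told apart here would separate at other concentrations.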